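Swapping the aminomethylphenyl group: what solubility to expect

The source may hold more compounds than are shown below. What is called first, only, known or untested is meant among the compounds shown, and "the series" means these compounds.

Compound 1 `CC(C)(C)c1cc(C(=O)Nc2cccc(CN)c2)n(Cc2ccccc2)n1` was tested in a physicochemical assay for solubility, read by nephelometry, measured as kinetic solubility, at pH 2.0; a lower number here means a less soluble compound, a higher number a more soluble compound. In this assay compound 1 gives > 100 ug/mL, which is a limit of the assay rather than a number. Compound 2 `Cn1nc(C(C)(C)C)cc1C(=O)Nc1nc(CN)cs1` gives > 100 ug/mL, again a limit. Compound 3 `NCc1csc(NC(=O)c2cc3ccccc3o2)n1` gives > 100 ug/mL, also a limit. Going by the values given here, the shared picture is the limit of > 100 ug/mL in this assay, at which 3 of the 3 values shown sit, so none of the measured compounds shows where its solubility would fall as a number. Compound 4 `CC(C)(C)c1cc(C(=O)Nc2nc(CO)cs2)n(Cc2ccccc2)n1` differs from compound 1 by a single change: 4-(hydroxymethyl)-1,3-thiazol-2-yl in place of 3-(aminomethyl)phenyl on an amide-type nitrogen. Among the compounds with values here, no measured step of this kind is available, so the direction rests on the change alone; a drop in solubility beyond the scatter is expected, and the step from compound 1 to compound 4 is estimated as an at least 3.3-fold lower number from compound 1 to compound 4 (0.52 log units; beyond the scatter). Compound 4 is therefore expected near 30 ug/mL, within 5 ug/mL to 100 ug/mL.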

Compound 4, solubility: 12.5 ug/mL
Compound 4: the middle estimate sits 2.4-fold (0.38 log units) above what was measured, and the stated range covers the measured number.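

Placing 4-(hydroxymethyl)-1,3-thiazol-2-yl on the amide-type nitrogen in place of 3-(aminomethyl)phenyl gives an at least 8.0-fold lower number from compound 1 to compound 4 (0.90 log units; beyond the scatter), so a change at this position can move solubility beyond the scatter. Compound 4 is also the only compound here with a measured number rather than a limit, and the others leave the ceiling as the shared picture: the limit of > 100 ug/mL in this assay, at which 3 of the 4 values shown sit.

The ring and the side chain change together, so the compounds shown do not separate their contributions. A 3-(hydroxymethyl)phenyl group on the same nitrogen would change only the side chain, leaving its solubility an open question.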